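This account rests on a few compounds, and the source may have more. Where it says the series, first, only, none or still open, it means among the compounds named here.

Measured compounds:
- compound 1 `O=C(NCc1ccc(F)cc1)c1nc(Br)c2cccnc2c1NCCCNc1c(C(=O)NCc2ccc(F)cc2)nc(Br)c2cccnc12`: > 20000 nM
- compound 2 `C[C@H](CO)Nc1nc(C(=O)NCc2ccc(F)cc2)c(O)c2ncccc12`: "not determined" (no result reported)
- compound 3 `CNCCCNc1c(C(=O)NCc2ccc(F)cc2)nc(Br)c2cccnc12`: > 10000 nM

In a functional assay on HCT-116 cells (Homo sapiens) for cytotoxicity, read by MTT assay, with a stated time of 72 h (a higher number here means a weaker inhibitor, a lower number a stronger inhibitor), compound 1 gives > 20000 nM, which is a limit of the assay and not a number. For compound 2 this assay reports "not determined" (no result reported). Compound 3 gives > 10000 nM in this assay, again a limit and not a number. Within the data shown here, compound 3 therefore stands at the limit of > 10000 nM in this assay, at which 1 of the 3 values shown sits, with the one other reported value of the series sitting at the limit of > 20000 nM in this assay, at which 1 of the 3 values shown sits; no single number is known for any compound, so no step between measured compounds can be sized.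

Compound 4 `CNc1c(C(=O)NCc2ccc(F)cc2)nc(Br)c2cccnc12` differs from compound 3 by hydrogen in place of 2-(methylamino)ethyl on a saturated chain carbon bound to a nitrogen on an aromatic ring. Among the measured compounds shown here, with compound 3 showing only a limit, and no measured step to lean on, the change is expected to leave compound 4 in the same region, with no shift beyond the scatter that could be resolved; the step from compound 3 to compound 4 is estimated at a step that the limit leaves unreadable from compound 3 to compound 4. Compound 4 is expected to give about 20000 nM in this assay, most likely reported again as a limit, within a range of 5000 nM to 80000 nM.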

Compound 4, half-maximal inhibitory concentration: > 20000 nM
Compound 4: no number, only a limit; the forecaster's own chance of this, stated with the estimate: 80%; the middle value lies on the limit itself.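

Among these compounds, compound 3 and compound 4 each carry only a limit and not a number in this assay, so no step between them can be read. The compounds shown leave open whether any member of the series gives a measurable value in this assay, and what the change from 3-(methylamino)propyl to methyl does to that value.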